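Chloro Substitution on a Benzoyl Hydrazide Sulfonamide

A few compounds are considered here, and "the series" means these few. Any claim that something is new, unique, unknown or untested is made for them only; others in the source may bear on it.

Measured compounds:
compound 1, `NS(=O)(=O)c1ccc(C(=O)NNC(=O)c2ccccc2)cc1`, 62800 nM
compound 2, `Cc1ccc(-c2nnc(-c3cccc(S(N)(=O)=O)c3)o2)cc1`, 61400 nM
compound 3, `NS(=O)(=O)c1ccc(-c2nnc(-c3ccc(Cl)c(Cl)c3)o2)cc1`, 46200 nM

Three sulfonamides were tested in an assay on cells for inhibition of Amine oxidase [flavin-containing] A (Homo sapiens), read by fluorescence and spectrophotometry, using microsomes, with a stated time of 20 min; a higher number here means a weaker inhibitor, a lower number a stronger inhibitor. Compound 1 gives the highest number of the three, yet its distance from compound 2 and from compound 3 lies within the usual scatter, so the three cannot be told apart on these numbers.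

Compound 4, `NS(=O)(=O)c1ccc(C(=O)NNC(=O)c2ccc(Cl)cc2)cc1`, is not yet measured. It differs from compound 1 by one change: chloro in place of hydrogen on an aromatic carbon. For the measured compounds named here, no step between measured compounds covers this change, so no measured step can guide the estimate. The step of a 1.5-fold lower number from compound 1 to compound 4 (0.17 log units; within the scatter) is expected to be small, a modest decrease that need not reach beyond the scatter. Compound 4 is therefore estimated at 42000 nM, with a range from 15000 nM to 120000 nM.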

Compound 4, half-maximal inhibitory concentration: 55900 nM
Beside the measured number, compound 4's estimate is 1.3-fold (0.12 log units) below it; the measured number falls inside the stated range.
By their numbers in this assay, from the lowest: compounds 3, 4, 2 and 1 (each within the scatter of the next).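

In this assay, for the compounds shown here, the change from phenyl to 4-chlorophenyl gives the first single-change step in this set (a 1.1-fold lower number from compound 1 to compound 4 (0.05 log units; within the scatter)). Chloro in place of hydrogen at this aromatic carbon, para to a large group, therefore leaves the number within the scatter of compound 1. No measurement shown bears on this result. As far as these compounds go, whether an amine, a carboxylic acid or a methoxy group at this position would take the number beyond the scatter remains open. So does whether chloro elsewhere on this ring would do so.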